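The source may report more compounds than this note shows. Statements on the series, on what has been measured and on what is new or still open speak of the compounds shown alone.

Measured in an ADME assay on the whole organism (Rattus norvegicus, strain Wistar Han) for metabolic stability; a lower number here means slower removal, a higher number faster removal of the compound:
- compound 1 `CCn1c(-c2ccc(C(F)(F)F)nc2)nc2c(O[C@H]3CCN(C(=O)C4CCOC4)C3)ncnc21` gives 19 mL/min/kg
- compound 2 `CCn1c(-c2cnc(C)nc2)nc2c(N[C@H]3CCN(C(=O)[C@H]4C[C@@H](OC)C4)C3)ncnc21` gives 81 mL/min/kg
- compound 3 `CCn1c(-c2cnc(C)nc2)nc2c(O[C@H]3CCN(C(=O)N4CC(OC)C4)C3)ncnc21` gives 25 mL/min/kg

Compound 2 has the highest number of the three, and its gaps to compound 1 and compound 3 both lie beyond the scatter. Compound 4 `CCn1c(-c2cnc(C)nc2)nc2c(N[C@H]3CCN(C(=O)C4CC4)C3)ncnc21` changes one group of compound 2: cyclopropyl in place of 3-methoxycyclobutyl on a carbonyl carbon, with cyclopropyl in place of 3-methoxycyclobutyl on a carbonyl carbon. Within the data shown here, no two measured compounds differ in only one place, so no measured step guides this change. A small fall in this assay, within the scatter, is expected because compound 2 starts at 81 mL/min/kg, the top of this small set. The expected step is a 1.4-fold lower number from compound 2 to compound 4 (0.13 log units; within the scatter). For compound 4 the estimated clearance is 60 mL/min/kg, with a range of 30 mL/min/kg to 110 mL/min/kg.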

Compound 4, clearance: 64 mL/min/kg
Beside the measured number, compound 4's estimate is 1.1-fold (0.03 log units) below it, within the range that was stated.
By their numbers in this assay, from the lowest: compounds 1 and 3 (each within the scatter of the next); then compounds 4 and 2 (each within the scatter of the next).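

Among these compounds, this is the first step that changes only one place, the group on a carbonyl carbon whose other neighbour is an amide-type nitrogen in a ring. In this assay cyclopropyl in place of 3-methoxycyclobutyl gives a 1.3-fold lower number from compound 2 to compound 4 (0.10 log units; within the scatter) and so leaves the two compounds inseparable, even though the group that leaves carries an oxygen and 2 defined stereocentres. No measurement here offers an explanation for this result.

From the compounds shown here alone, whether a plain cyclobutyl would read like either group remains open. So does whether an amine or a longer chain on this carbonyl carbon would move clearance beyond the scatter.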